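The source may hold more compounds than are shown below. What is called first, only, known or untested is meant among the compounds shown, and "the series" means these compounds.

Compound 1 `COc1cc2cc(C(=O)CCC3CC[N+](C)(Cc4ccccc4)CC3)sc2cc1OC` and compound 2 `COc1cc2cc(C(=O)CC(O)CCC3CC[N+](C)(Cc4ccccc4)CC3)sc2cc1OC` share a core and a charged benzylated piperidinium tail, and differ only in the chain that joins them. In a physicochemical assay for solubility (on this read-out lower numbers stand for lower solubility and higher numbers for higher solubility), compound 1 gives 2000 ug/mL. In this assay compound 2 gives 2500 ug/mL, and the gap between the two numbers lies within the usual scatter, so the two cannot be told apart on these data; compound 2 simply carries the higher-printed figure of the pair.

Compound 3 `COc1cc2cc(C(=O)CCCCC3CC[N+](C)(Cc4ccccc4)CC3)sc2cc1OC` has not yet been measured. It differs from compound 2 by hydrogen in place of hydroxy on a saturated chain carbon bound to two saturated chain carbons, which leaves a chain of the same length as in compound 2 but without its hydroxy group. Among the compounds with values here, no measured pair in this set shows that exact change, so the expectation rests only on compound 1 and compound 2, whose numbers sit close together with or without the hydroxy group on a shorter chain.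

Compound 3 is therefore expected to stay in the same region: the step of a 1.4-fold lower number from compound 2 to compound 3 (0.14 log units; within the scatter) is estimated to be small, at most a slight drop, and not clearly beyond the scatter. Compound 3 is estimated at 1800 ug/mL, with a likely range from 900 ug/mL to 3200 ug/mL.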

Compound 3, solubility: 1000 ug/mL
The estimate for compound 3 lay 1.8-fold (0.26 log units) above the measured number; measured number inside the range.
By their numbers in this assay, from the lowest: compounds 3, 1 and 2 (each within the scatter of the next, the first and the last beyond it).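

In this assay, within the data shown here, this is the first look at a single change at this place: hydrogen in place of hydroxy on a saturated chain carbon bound to two saturated chain carbons, with the chain otherwise the same, goes with a 2.5-fold lower number from compound 2 to compound 3 (0.40 log units; beyond the scatter). The earlier pair, whose numbers lay within the scatter of each other, also differed in the chain itself and so could not speak for this position alone; here the position proves not to be indifferent to what it carries, although the step is only modest. Nothing available explains why the number moves with this change.

What the compounds shown leave open is how other groups would fare on this same saturated chain carbon, such as an amine, a carboxylic acid or a methoxy group, and whether their numbers would stand nearer that of compound 2 or that of compound 3. Also open, as far as these compounds go, is whether the same exchange of hydroxy for hydrogen gives a step of similar size on a longer chain.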